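Removing the Chloro Group from Compound 1

The compounds below may be only part of what the source reports. "The series", "measured", "known", "first", "only" and "open" are said of these compounds alone.

Compound 1 `Clc1ccccc1-c1cc(-c2cnn(C3CCNCC3)c2)on1` and compound 2 `Cc1c(-c2cc(-c3ccccc3Cl)no2)cnn1C1CCNCC1` share one core and have both been tested in an assay on isolated protein for positive allosteric modulation of Neuronal acetylcholine receptor; alpha4/beta2 (Homo sapiens); a lower number here means that less compound is needed, a higher number that more compound is needed for the effect. In this assay, among the compounds with values here, compound 1 gives 120 nM, the highest of the two numbers known so far. Within the data shown here, compound 2 gives 18 nM in this assay; the single change between the two, methyl in place of hydrogen on an aromatic carbon, produced a 6.7-fold lower number from compound 1 to compound 2 (0.82 log units; beyond the scatter).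

Compound 3 `c1ccc(-c2cc(-c3cnn(C4CCNCC4)c3)on2)cc1` has not yet been measured. It differs from compound 1 by hydrogen in place of chloro on an aromatic carbon of a six-membered aromatic ring of carbon only, ortho to a large group; cut one bond further out, the change reads 2-chlorophenyl to phenyl. Among the measured compounds shown here, no measured step touches this place. For the measured compounds named here, the one step known, which added a methyl on another ring, says nothing about losing the chloro. With no measured guide to direction, the expected step of a 2.1-fold higher number from compound 1 to compound 3 (0.32 log units; beyond the scatter) is set as a small rise in the number, with wide uncertainty. Compound 3 is therefore expected to give about 250 nM in this assay, within a range from 60 nM to 1000 nM.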

Compound 3, half-maximal effective concentration: 100000 nM
Compound 3: the middle estimate sits 400-fold (2.60 log units) below what was measured, and the stated range ends below it.
By their numbers in this assay, from the lowest: compound 2; then compound 1; then compound 3.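

In this assay, the change from 2-chlorophenyl to phenyl gives an 830-fold higher number from compound 1 to compound 3 (2.92 log units; beyond the scatter), so this one chlorine atom, the only heavy atom that leaves, is far from a spare part of compound 1. Within the data shown here, the only earlier step, a 6.7-fold lower number from compound 1 to compound 2 (0.82 log units; beyond the scatter), was modest, pointed the other way and lay on another ring, so it gave no sign that the chloro position could matter this much: within this small set, the largest shift comes from removing a single atom rather than from adding one. Nothing measured here explains why so small a change has so large an effect.

The compounds shown leave open whether the chloro itself is needed or whether another group in the same place, such as fluoro, bromo, methyl or methoxy, would keep the number low. They also leave open whether the methyl that separates compound 2 from compound 1 would lower the number in the same way on a compound carrying phenyl in place of 2-chlorophenyl.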